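The source may hold more compounds than are shown below. What is called first, only, known or untested is meant among the compounds shown, and "the series" means these compounds.

Working notes on the series. In a functional assay on Bel-7402 cells (Homo sapiens) for inhibition, read by MTT assay, with a stated time of 24 h, tested at 100 ug/mL (on this read-out higher numbers stand for more inhibition of growth at the one concentration tested and lower numbers for less inhibition of growth), compound 1 (`CC(=O)SCCC(CCCCC(=O)O)SC(C)=O`) gives 8.35% and compound 2 (`Cc1cccc(NC(=O)CCCCC(S)CCS)c1`) gives 7.08% and these two values lie within the usual scatter of each other. Compound 3 (`CC(=O)SCCC(CCCCC(=O)Nc1ccccc1Cl)SC(C)=O`) has no single number: it is recorded as "not active" (no number reported) in this assay and so cannot be placed numerically against the other two. Compound 4 (`CC(=O)SCCC(CCCCC(=O)Nc1ccc(Cl)cc1)SC(C)=O`) differs from compound 3 at one place (4-chlorophenyl in place of 2-chlorophenyl on an amide-type nitrogen) with 4-chlorophenyl in place of 2-chlorophenyl on an amide-type nitrogen and the rest of the structure unchanged. Going by the values given here, no measured pair shows the effect of such a change. The expectation therefore rests on the low readings of compound 1 at 8.35% and compound 2 at 7.08% and no step beyond the scatter is expected in this assay in either direction. For compound 4 the expected value is 8% with an estimated range from 0% to 20% as the likely span of the measurement.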

Compound 4, percent growth inhibition at one concentration: 45.5%
Compound 4: middle estimate off by 37.5 percentage points, on the low side; the measured number lies above the stated range.
By their numbers in this assay, from the lowest: compounds 2 and 1 (each within the scatter of the next); then compound 4.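

In this assay, going by these compounds alone, (4-chlorophenyl)amino in place of hydroxy on a carbonyl carbon gives a number 37.2 percentage points higher from compound 1 to compound 4 (beyond the scatter), the first step to lie beyond the scatter. Compound 3, with the same atoms but 2-chlorophenyl on the amide-type nitrogen, is recorded as not active, whereas compound 4 gives 45.5%, so the two chlorophenyl groups are not interchangeable here, although the step between them cannot be read as a number. No measurement available here bears on the reason for this difference.

On these data alone, it remains open whether the gain depends on the chlorine itself, which phenyl, 4-bromophenyl or 4-methoxyphenyl on the same nitrogen would address. Also open, as far as these compounds go, is how the 4-chlorophenyl amide behaves with free thiol groups in place of the acetyl groups on sulfur.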